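The source may report more compounds than this note shows. Statements on the series, on what has been measured and on what is new or still open speak of the compounds shown alone.

Measured compounds:
compound 1 `CCN(CC)c1nc(C)nc2c1nnn2-c1ccc(C(C)C)cc1Br` 25.3 nM
compound 2 `CCCCN(CC)c1nc(C)nc2c1nnn2-c1ccc(C(C)C)cc1Br` 7.5 nM
compound 3 `CCCC(CN(C)C)Nc1nc(C)nc2c1nnn2-c1ccc(C(C)C)cc1Br` 38.7 nM

In an in vitro assay on 293-EBNA cells for binding affinity to corticotropin-releasing factor receptor 1 (Homo sapiens) (on this read-out higher numbers stand for weaker inhibition and lower numbers for stronger inhibition), compound 3 gives the highest number of the three. Its nearest neighbour is compound 1, a 1.5-fold higher number from compound 1 to compound 3 (0.18 log units; within the scatter), and its furthest is compound 2, a 5.2-fold higher number from compound 2 to compound 3 (0.71 log units; beyond the scatter). Compound 4 `COCCCNc1nc(C)nc2c1nnn2-c1ccc(C(C)C)cc1Br` differs from compound 3 in that (a group of 5 heavy atoms (4 carbon, 1 oxygen; no ring) in place of a group of 8 heavy atoms (7 carbon, 1 nitrogen; no ring), on a nitrogen on an aromatic ring). Among the measured compounds shown here, the steps that bear on this are those that reshape the group on the same nitrogen: a 1.5-fold higher number from compound 1 to compound 3 (0.18 log units; within the scatter) and a 5.2-fold higher number from compound 2 to compound 3 (0.71 log units; beyond the scatter), both showing lower numbers for the shorter chains of compound 1 and compound 2. A modest move toward a lower number is therefore expected for compound 4, estimated at 20 nM (range 6 nM to 65 nM), a step of a 1.9-fold lower number from compound 3 to compound 4 (0.29 log units; within the scatter).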

Compound 4, inhibition constant: 291 nM
Beside the measured number, compound 4's estimate is 15-fold (1.16 log units) below it; the whole stated range lies below it.
By their numbers in this assay, from the lowest: compound 2; then compounds 1 and 3 (each within the scatter of the next); then compound 4.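

In this assay, among the compounds shown here, putting 3-methoxypropyl on this nitrogen gives a 7.5-fold higher number from compound 3 to compound 4 (0.88 log units; beyond the scatter), so a change here can weaken inhibition far more than the earlier compounds showed. The gaps to the diethylamino and butyl(ethyl)amino compounds are wider still, with a 12-fold higher number from compound 1 to compound 4 (1.06 log units; beyond the scatter) and a 39-fold higher number from compound 2 to compound 4 (1.59 log units; beyond the scatter). No supporting data bear on what lies behind this shift.

The compounds shown leave open whether the ether oxygen of the chain matters or the change of chain as a whole. An unbranched butyl or a 3-hydroxypropyl group on the same nitrogen would help separate these.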